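From 4-Nitrophenyl to 4-Aminophenyl

A few compounds are considered here, and "the series" means these few. Any claim that something is new, unique, unknown or untested is made for them only; others in the source may bear on it.

In a functional assay on HCT-116 cells (Homo sapiens) for inhibition, read by MTT assay, with a stated time of 48 h (a higher number here means a weaker inhibitor, a lower number a stronger inhibitor), compound 1 `COc1cc(-c2nccn3cc(-c4ccccc4)nc23)cc(OC)c1OC` gives 266 nM. Compound 2 `COc1cc(-c2nccn3cc(-c4ccc([N+](=O)[O-])cc4)nc23)cc(OC)c1OC`, with nitro in place of hydrogen on an aromatic carbon, gives > 10000 nM, which is a limit and not a number. Its true position in this assay is therefore unknown.

Compound 3 `COc1cc(-c2nccn3cc(-c4ccc(N)cc4)nc23)cc(OC)c1OC` has amino in place of nitro on an aromatic carbon, para to a large group: amino in place of nitro on an aromatic carbon. Going by the values given here, only one measured step bears on this change, and it is large and beyond the scatter: an at least 37-fold higher number from compound 1 to compound 2 (1.57 log units; beyond the scatter). Among the compounds with values here, no measured step shows what an amino group does on this ring, so the evidence is thin. With the nitro gone, much of that loss is expected to be recovered, and compound 1 at 266 nM serves as the nearest guide, although amino is not hydrogen. The expected change is an at least 16-fold lower number from compound 2 to compound 3 (1.22 log units; beyond the scatter), a large move toward a lower number, but its size is only an estimate. For compound 3 the estimated value is 600 nM, with an expected range from 100 nM to 5000 nM.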

Compound 3, half-maximal inhibitory concentration: 158 nM
For compound 3 the middle estimate is 3.8-fold (0.58 log units) above the measured one; low and high end bracket the measured number.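

In this assay compound 2 gives > 10000 nM, which is a limit and not a number: the limit of > 10000 nM in this assay, at which 1 of the 3 values shown sits. Amino in place of nitro gives an at least 63-fold lower number from compound 2 to compound 3 (1.80 log units; beyond the scatter), so the earlier loss does not follow from every group on this aromatic carbon; the size of that step stays open-ended, as it rests on the limit. The comparison with the hydrogen of the parent gives a 1.7-fold lower number from compound 1 to compound 3 (0.23 log units; within the scatter), so in this assay amino and hydrogen on this carbon cannot be told apart, which the earlier pair, with only nitro as a substituent, could not show.

With only hydrogen, nitro and amino on this carbon, the compounds shown do not reveal which feature separates nitro from amino, and neither the nitro nor the amino result says how a hydroxyl, a methoxy, an acetamide or a carboxylic acid would fall. They also leave open whether a dimethylamino group or a longer aminoalkyl chain in this place would stay level with amino or move toward the limit seen for compound 2.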